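A few compounds are considered here, and "the series" means these few. Any claim that something is new, unique, unknown or untested is made for them only; others in the source may bear on it.

Measured compounds:
- compound 1 `Nc1nc(Cl)c2ncn(Cc3ccccc3CCl)c2n1` gives 5750 nM in a functional assay on ACHN cells (Homo sapiens) for cytotoxicity, read by sulforhodamine B assay, with a stated time of 48 h; a higher number here means a weaker inhibitor of growth, a lower number a stronger inhibitor of growth
- compound 2 `ClCc1ccccc1Cn1cnc2nc(Cl)nc(Cl)c21` gives 350 nM in this assay

Compound 2 stands lowest of the two numbers in this assay. The nearest neighbour is compound 1, whose number is higher by a margin beyond the scatter of the assay; the two share the core of compound 2 and differ only in the group on the same ring carbon that is altered in the step treated here. Going by the values given here, no step between measured compounds is at hand, so the expectation for the next compound rests on that comparison alone.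

Compound 3 `ClCc1ccccc1Cn1cnc2ncnc(Cl)c21` is the unmeasured member. Relative to compound 2 the change is hydrogen in place of chloro on an aromatic carbon, a hydrogen in place of chloro on an aromatic carbon of the six-membered aromatic ring with 2 nitrogen in the fused system of two rings.

The numbers for compound 1 and compound 2 show that a change at this carbon can move the result well beyond the scatter, but the direction of a hydrogen there is not shown. For compound 3 a step of a 3.4-fold higher number from compound 2 to compound 3 (0.54 log units; beyond the scatter) toward a higher number is expected, with wide uncertainty. The estimate for compound 3 in this assay is 1200 nM, within a range of 400 nM to 4000 nM.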

Compound 3, concentration for 50% growth inhibition: 1990 nM
Compound 3: middle estimate off by 1.7-fold (0.22 log units), on the low side, and the stated range covers the measured number.
By their numbers in this assay, from the lowest: compound 2; then compound 3; then compound 1.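

In this assay hydrogen in place of chloro gives a 5.7-fold higher number from compound 2 to compound 3 (0.75 log units; beyond the scatter) and so fixes the direction that the earlier pair left unknown: on this aromatic carbon between two ring nitrogen atoms, the chloro goes with the lower number and the stronger inhibition of growth. Hydrogen also does not reproduce the result of the amino group on the same carbon, since compound 3 gives (1990 nM) while compound 1 gives (5750 nM), and among these three groups the number is lowest with chloro. No measurement on hand bears on why the step occurs, so the result stands as an observation on these compounds only.

Still open, on these data alone, is how other groups on this carbon would rank against chloro, hydrogen and amino, for example fluoro, bromo, methoxy or a methyl group. The compounds shown also leave open whether the same step would hold with the other chloro of the shared core replaced by a group such as methoxy, or in cell lines other than this one.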